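The source may hold more compounds than are shown below. What is called first, only, known or untested is meant among the compounds shown, and "the series" means these compounds.

In a functional assay on A549 cells (Homo sapiens) for cytotoxicity, read by XTT assay, with a stated time of 24 h (a higher number here means a weaker inhibitor, a lower number a stronger inhibitor), compound 1 `Cn1nnnc1SCC(=O)N/N=C/c1ccccc1` gives 3160000 nM and stands highest of the two numbers recorded so far. The nearest compound is compound 2 `Cn1nnnc1SCC(=O)N/N=C/c1ccc(Cl)cc1`, which in this assay gives 100000 nM and differs from compound 1 by a single change. That one measured step, a 32-fold lower number from compound 1 to compound 2 (1.50 log units; beyond the scatter), is large and well beyond the scatter. Compound 3 `Cn1nnnc1SCC(=O)N/N=C/c1cccc([N+](=O)[O-])c1` has not yet been measured in this assay and differs from compound 1 by nitro in place of hydrogen on an aromatic carbon. Going by the values given here, no measured step involves a nitro group, so the only comparison available is the chloro step seen with compound 2, a different group on the same ring. On that slender basis a lower number than that of compound 1 is expected for compound 3, though a more modest one, and the expected step is a 5.3-fold lower number from compound 1 to compound 3 (0.72 log units; beyond the scatter) in this assay. Compound 3 is therefore estimated at 600000 nM with a range from 120000 nM to 3000000 nM in this assay.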

Compound 3, half-maximal inhibitory concentration: > 10000000 nM
Compound 3 gave a limit, no number; the forecaster's own chance of this, stated with the estimate: 25%; middle value at least 16-fold (1.22 log units) from the limit.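

For compound 3 the result in this assay is a limit and not a number: the limit of > 10000000 nM in this assay, at which 1 of the 3 values shown sits. Even so, its direction can be read, and the nitro change gives an at least 3.1-fold higher number from compound 1 to compound 3 (0.50 log units; beyond the scatter) in contrast to the fall seen with chloro in compound 2. A group placed on this ring can therefore move the number either way from compound 1, so replacing hydrogen here does not by itself lower it.

Compound 2 and compound 3 differ in both the group and its place on the ring, so the compounds shown do not separate the effect of one from the other. Going by these compounds, what chloro, an amine or a methoxy group would give on the aromatic carbon that carries the nitro group stays open.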